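The source may report more compounds than this note shows. Statements on the series, on what has been measured and on what is new or still open speak of the compounds shown alone.

Of the compounds shown here, two have been measured in an assay on cells for inhibition of sodium channel protein type 3 subunit alpha (Homo sapiens), read by electrophysiology; a higher number here means a weaker inhibitor, a lower number a stronger inhibitor. Compound 1 `O=C(COc1ccc(F)cc1)N1CCc2cc(S(=O)(=O)Nc3nccs3)ccc21` gives 2510 nM. Compound 2 `O=S(=O)(Nc1nccs1)c1ccc(-c2nnc(Cc3ccc(Cl)c(Cl)c3)[nH]2)cc1` gives 45 nM, the lowest of the two numbers; compound 1, its nearest neighbour, sits at a number higher by a margin well beyond the scatter. Among the measured compounds shown here, these two compounds differ in many places at once, so their values show only that compound 2 is the stronger inhibitor of the pair, not which part of the structure accounts for it.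

Compound 3 `O=S(=O)(Nc1nccs1)c1ccc(-c2nnc(Cc3ccc(C(F)(F)F)cc3)[nH]2)cc1` is not yet measured. It differs from compound 2 in one place: 4-(trifluoromethyl)phenyl in place of 3,4-dichlorophenyl on a saturated chain carbon bound to an aromatic carbon. For the measured compounds named here, no step between measured compounds that differ in a single place is available. On that basis a step of modest size in this assay is expected, within the scatter or slightly toward a higher number, as in a 1.8-fold higher number from compound 2 to compound 3 (0.25 log units; within the scatter). Compound 3 is therefore estimated at 80 nM, with a range from 25 nM to 250 nM.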

Compound 3, half-maximal inhibitory concentration in the sodium channel protein type 3 subunit alpha assay: 124 nM
Estimate against measurement, compound 3: 1.6-fold (0.19 log units) below, and the stated range covers the measured number.
By their numbers in the sodium channel protein type 3 subunit alpha assay, from the lowest: compound 2; then compound 3; then compound 1.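

In the sodium channel protein type 3 subunit alpha assay compound 2 gives 45 nM and compound 3 gives 124 nM. Among the compounds shown here, in the sodium channel protein type 3 subunit alpha assay, putting 4-(trifluoromethyl)phenyl in place of 3,4-dichlorophenyl on a saturated chain carbon bound to an aromatic carbon gives a 2.8-fold higher number from compound 2 to compound 3 (0.44 log units; beyond the scatter), the first comparison here in which only one place changes. The rest of the molecule stays the same. This shift can be tied to that single exchange: the step is modest, and inhibition weakens without being lost, so this position accepts more than one substituted phenyl. Nothing available here explains why the two groups differ.

As far as these compounds go, it remains open whether a single chlorine, a methoxy group on the phenyl, an unsubstituted phenyl or a longer chain would do better or worse at this place. In a physicochemical assay for lipophilicity (on this read-out higher numbers stand for higher lipophilicity and lower numbers for lower lipophilicity), compound 2 is recorded as "not determined" (no result reported) and compound 3 as "not determined" (no result reported), so no step can be read there.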